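Bromo to chloro in a cytotoxicity test

A few compounds are considered here, and "the series" means these few. Any claim that something is new, unique, unknown or untested is made for them only; others in the source may bear on it.

Measured in a toxicity assay on THP-1 cells (Homo sapiens) for inhibition; on this read-out higher numbers stand for lower toxicity in this test and lower numbers for higher toxicity in this test:
Compound 1 `Cn1c(-c2ccc(Br)cc2)cnc1NC(=O)c1ccc(F)cc1`: 46000 nM
Compound 2 `CCC(=O)Nc1ncc(-c2ccc(OC)cc2)n1C`: > 100000 nM, a limit
Compound 3 `Cn1cc(-c2ccccc2)nc1NC(=O)c1ccc(F)cc1`: > 50000 nM, a limit

Compound 1 stands alone as the only one of the three with a real number, 46000 nM. Compound 2 reaches only a limit, > 100000 nM. Compound 3 likewise reaches only a limit, > 50000 nM. Neither limit gives compound 1 an exact rank.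

Compound 4 `Cn1c(-c2ccc(Cl)cc2)cnc1NC(=O)c1ccc(F)cc1` keeps the rest of compound 1 and carries a single exchange, chloro in place of bromo on an aromatic carbon, para to a large group: chloro in place of bromo on an aromatic carbon. Going by the values given here, no measured pair shows this exchange, so the expectation rests on compound 1, with its 46000 nM, and on the modest nature of swapping one halogen for another. The expected change, a 1.2-fold higher number from compound 1 to compound 4 (0.08 log units; within the scatter), stays within the usual scatter and has no firm direction. Compound 4 could also return only a limit in this assay. For compound 4 the estimated value is 55000 nM, with an expected range from 28000 nM to 100000 nM.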

Compound 4, half-maximal cytotoxic concentration: 37000 nM
Compound 4: middle estimate off by 1.5-fold (0.17 log units), on the high side; measured number inside the range.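

In this assay the only pair shown that differs at this place gives a 1.2-fold lower number from compound 1 to compound 4 (0.09 log units; within the scatter) and so offers the first direct reading of the exchange from 4-bromophenyl to 4-chlorophenyl. On the shared core, the two halogens cannot be told apart in this test, and like compound 1, compound 4 returns a real number and not a limit. Nothing measured here accounts for the size of this step.

Still open, as far as these compounds go, is whether a group of another kind at this place, such as an amine, a carboxylic acid or a longer chain, would move the number beyond the scatter. Iodo or fluoro on the same aromatic carbon would show whether other halogens also stay this close to bromo and chloro.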